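Methoxy for Hydrogen on a Furan-Fused Core

The compounds below may be only part of what the source reports. "The series", "measured", "known", "first", "only" and "open" are said of these compounds alone.

Of the compounds shown here, two from this study have been tested in a functional assay on MCF7 cells (Homo sapiens) for antiproliferative activity; on this read-out higher numbers stand for weaker inhibition and lower numbers for stronger inhibition. Compound 1 `COc1c(C(/C=C(\C)N2CCCC2)=C2C(=O)c3ccccc3C2=O)c(O)cc2occc12` gives 15.5 ug/mL. Compound 2 `COc1c2c(cc3occc13)OC1(CCCCC1)C/C2=N\NC(N)=O`, built on a different core, gives 14 ug/mL in this assay, a number that sits within the usual scatter of the value of compound 1, so the two cannot be told apart on these data.

Compound 3 `COc1c2c(c(OC)c3occc13)OC1(CCCCC1)C/C2=N\NC(N)=O` is the third member of the series and has not yet been measured. It differs from compound 2 by methoxy in place of hydrogen on an aromatic carbon. Within the data shown here, no step between measured compounds shows what such a change does on this core, and the two measured numbers give no trend to lean on. The change is therefore expected to move the number in this assay little, if at all, and in no particular direction, with no change at the digits printed from compound 2 to compound 3 (within the scatter) as the estimated step. Compound 3 is expected to give about 14 ug/mL in this assay, with a likely range from 5 ug/mL to 40 ug/mL.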

Compound 3, half-maximal inhibitory concentration: 10.6 ug/mL
Estimate against measurement, compound 3: 1.3-fold (0.12 log units) above; the measured number falls inside the stated range.
By their numbers in this assay, from the lowest: compounds 3, 2 and 1 (each within the scatter of the next).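

In this assay, among these compounds, the change of methoxy in place of hydrogen gives the first step on this core, a 1.3-fold lower number from compound 2 to compound 3 (0.12 log units; within the scatter), and that step lies within the scatter. The aromatic carbon para to a methoxy group therefore carries the added methoxy with no difference that these numbers can separate from repeat measurement, which the two earlier compounds, built on different cores, could not show. No available measurement bears on the reason for this result.

From the compounds shown here alone, whether an ethoxy group, an amine or a carboxylic acid on the same carbon would also stay within the scatter remains open. With a single step at this position, the compounds shown also leave open whether any substituent there can move the number beyond the scatter.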